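A few compounds are considered here, and "the series" means these few. Any claim that something is new, unique, unknown or untested is made for them only; others in the source may bear on it.

In a functional assay on the whole organism for inhibition, with Cavia porcellus as the target (a higher number here means that more compound is needed for the effect, a lower number that less compound is needed), compound 1 (`COc1ccc(OCC2SCCN2C(=O)Cn2ccnc2)cc1`) gives 48 mg/kg, compound 2 (`COc1ccccc1OCC1SCCN1C(C)=O`) gives 46 mg/kg and compound 3 (`O=C(O)CC(=O)N1CCSC1COc1ccccc1O`) gives 25 mg/kg. These three numbers lie within the usual scatter of one another, so compound 2 cannot be told apart from either neighbour. Compound 4 (`CNC(=O)CC(=O)N1CCSC1COc1ccccc1OC`) is built from compound 2 by one change: methylcarbamoyl in place of hydrogen on a saturated chain carbon bound to a carbonyl carbon. For the measured compounds named here, no measured pair shows this change alone. Going by the values given here, the compounds tested so far differ in several places yet stay within the scatter, so no shift beyond the scatter is expected. The estimated step of a 1.2-fold lower number from compound 2 to compound 4 (0.06 log units; within the scatter) is therefore small. Compound 4 is expected at 40 mg/kg, within an estimated range of 18 mg/kg to 90 mg/kg.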

Compound 4, dose for half-maximal effect: 21 mg/kg
Beside the measured number, compound 4's estimate is 1.9-fold (0.28 log units) above it, and the stated range covers the measured number.
By their numbers in this assay, from the lowest: compounds 4, 3, 2 and 1 (each within the scatter of the next, the first and the last beyond it).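

In this assay, methylcarbamoyl in place of hydrogen on a saturated chain carbon bound to a carbonyl carbon gives a 2.2-fold lower number from compound 2 to compound 4 (0.34 log units; beyond the scatter), a modest step and the first here that reads a single change. This position therefore accepts the added group, and less compound is needed with it in place. No measurement shown explains the shift. Still open, from the compounds shown here alone, is whether a longer chain, such as ethylcarbamoyl, or an amine on the same carbon would give a similar step. A single pair also cannot show whether this step holds on other compounds.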